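A few compounds are considered here, and "the series" means these few. Any claim that something is new, unique, unknown or untested is made for them only; others in the source may bear on it.

Compound 1 `CN1C[C@@H](COc2ccc(C(=O)Nc3cccc(CC(=O)O)c3)c(Cl)c2)Oc2ccccc21` opens the set. In an assay on CHO cells for displacement of a labelled ligand from prostacyclin receptor (Homo sapiens), read by scintillation counting, with a stated time of 30 min (a lower number here means a stronger inhibitor, a higher number a weaker inhibitor), compound 1 gives 2700 nM. Compound 2 `Cc1ccc(CC(=O)O)cc1NC(=O)c1ccc(OC[C@@H]2CN(C)c3ccccc3O2)cc1Cl` differs from compound 1 in one place only, (methyl in place of hydrogen on an aromatic carbon). In this assay compound 2 gives 1400 nM, and the step is a 1.9-fold lower number from compound 1 to compound 2 (0.29 log units; within the scatter).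

Compound 3 `Cc1cc(OC[C@@H]2CN(C)c3ccccc3O2)ccc1C(=O)Nc1cc(CC(=O)O)ccc1Cl` is built on a second core; the difference between the two cores is not broken down here. In this assay compound 3 gives 1800 nM, a number that differs from those of compound 1 and of compound 2 by less than the usual scatter of such measurements.

Compound 4 `Cc1cc(C(=O)Nc2cc(CC(=O)O)ccc2Cl)c(C)cc1OC[C@@H]1CN(C)c2ccccc2O1` has not been measured. It differs from compound 3 by methyl in place of hydrogen on an aromatic carbon. Within the data shown here, this is the same kind of change as the one that turns compound 1 into compound 2, but not the same change: in compound 4 the entering methyl sits ortho to a large group, meta to a large group and para to a methyl group, whereas in compound 2 it sits ortho to a large group and para to a carboxymethyl group. Among the measured compounds shown here, the one measured example of this kind of change, a 1.9-fold lower number from compound 1 to compound 2 (0.29 log units; within the scatter), stays within the scatter, so only a small step is expected here too. The estimated step is a 1.5-fold lower number from compound 3 to compound 4 (0.18 log units; within the scatter), resting on that earlier step of the same kind. Compound 4 is therefore expected to give 1200 nM in this assay, with a likely range from 500 nM to 3000 nM.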

Compound 4, inhibition constant in the prostacyclin receptor assay: 1800 nM
Compound 4: the middle estimate sits 1.5-fold (0.18 log units) below what was measured, and the stated range covers the measured number.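

In the prostacyclin receptor assay the methyl in place of hydrogen on an aromatic carbon gives no change at the digits printed from compound 3 to compound 4 (within the scatter), and set beside the earlier step on the core of compound 1, the change reads alike on both cores: the same change on two cores in the prostacyclin receptor assay, a 1.9-fold lower number (0.29 log units; within the scatter) from compound 1 to compound 2 and no change at the digits printed (within the scatter) from compound 3 to compound 4, 1.9-fold (0.29 log units) apart, within the scatter of two such steps. For these two pairs, then, the methyl carries from one core to the other without a step beyond the scatter in receptor binding, but two pairs with the methyl entering at different places do not show that this holds on further cores, and steps this small do not show whether the methyl has any effect there at all. In a physicochemical assay for solubility, measured as kinetic solubility (a lower number here means a less soluble compound, a higher number a more soluble compound), compound 3 gives 129 ug/mL and compound 4 gives 17 ug/mL. In the physicochemical assay the same change on the core of compound 3 stands as a single case, which shows a real drop for this pair and cannot say whether that drop carries to another core: the measured solubility of compound 3, 129 ug/mL, and of compound 4, 17 ug/mL, a 7.6-fold lower number (0.88 log units; beyond the scatter).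

The compounds shown leave open whether a different group entering at the same place, such as a fluorine, an ethyl or a methoxy group, would follow the methyl in either read-out. They also leave open whether a methyl at another carbon of that ring would give the same result.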